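Removing the Halogen: Estimating Compound 4's Inhibition

The compounds below may be only part of what the source reports. "The series", "measured", "known", "first", "only" and "open" are said of these compounds alone.

Measured compounds:
compound 1 `Brc1ccc(OCCOc2nc3ccccc3s2)cc1`: 94.6%
compound 2 `Clc1ccc(OCCOc2nc3ccccc3s2)cc1`: 66.3%
compound 3 `Fc1ccc(OCCOc2nc3ccccc3s2)cc1`: 72.7%

Three compounds sharing one core were tested in a functional assay on the whole organism with Mus musculus as the target, with a stated time of 1 h, at a dose of 100 mg/kg by the intraperitoneal route; a lower number here means less inhibition, a higher number more inhibition at the dose given (going by the name of the read-out). Compound 3 stands second highest of the three: its gap to compound 2 is within the scatter, while compound 1 lies well above it, the change being a number 21.9 percentage points lower from compound 1 to compound 3 (beyond the scatter). Compound 4 `c1ccc(OCCOc2nc3ccccc3s2)cc1` differs from compound 3 by hydrogen in place of fluoro on an aromatic carbon. Within the data shown here, no measured step replaces a halogen by hydrogen, so the bearing is indirect: a number 28.3 percentage points lower from compound 1 to compound 2 (beyond the scatter) and a number 6.4 percentage points higher from compound 2 to compound 3 (within the scatter) show that changing the halogen shifts this assay modestly at most once bromo is gone. Compound 4 is therefore expected to give about 60%, within 35% to 85%. That estimate means an expected step of a number 12.7 percentage points lower from compound 3 to compound 4 (beyond the scatter), a modest fall not far beyond the scatter.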

Compound 4, a percentage reported as inhibition, in the whole organism at one dose (the size of the read-out at that dose, not a potency): 7.31%
Compound 4: middle estimate off by 52.7 percentage points, on the high side, and the stated range ends above it.
By their numbers in this assay, from the lowest: compound 4; then compounds 2 and 3 (each within the scatter of the next); then compound 1.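

At this place, on an aromatic carbon para to a large group, a halogen proved far more important than the choice of halogen. Hydrogen in place of fluoro gave a number 65.4 percentage points lower from compound 3 to compound 4 (beyond the scatter) and hydrogen in place of chloro gave a number 59 percentage points lower from compound 2 to compound 4 (beyond the scatter) while hydrogen in place of bromo gave a number 87.3 percentage points lower from compound 1 to compound 4 (beyond the scatter) as the largest fall. All three steps exceed every step among the halogens, so the earlier compounds had shown only a small part of what this position can do.

Going by these compounds, whether a methyl, a methoxy or an amine at this place would restore inhibition remains open, as does how the four compounds compare at other doses. Nothing available bears on the reason for this fall.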